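The compounds below may be only part of what the source reports. "The series", "measured", "known", "first", "only" and "open" are said of these compounds alone.

Compound 1 `CCCN(CCC)c1cc(C)nc2c(-c3ccc(Cl)cn3)c(C)nn12` is the starting point of this step. Among the compounds with values here, in an assay on isolated protein for binding affinity to corticotropin-releasing factor receptor 1 (Homo sapiens) (on this read-out lower numbers stand for stronger inhibition and higher numbers for weaker inhibition), compound 1 gives 88 nM, which places it second highest among the three numbers measured so far. Its nearest neighbour is compound 2 `CCCN(CCC)c1cc(C)nc2c(-c3ncc(N)cc3C)c(C)nn12`, which gives 85 nM in this assay, a move described by a 1.0-fold lower number from compound 1 to compound 2 (0.02 log units; within the scatter). The furthest is compound 3 `CCCN(CCC)c1cc(C)nc2c(-c3ncccc3C)c(C)nn12`, which gives 110 nM; the move from compound 1 to it is a 1.3-fold higher number from compound 1 to compound 3 (0.10 log units; within the scatter), and between the other two the move is a 1.3-fold higher number from compound 2 to compound 3 (0.11 log units; within the scatter). Every comparison so far therefore falls inside the usual scatter.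

The new compound is compound 4 `CCCN(CCC)c1cc(C)nc2c(-c3ncc(C)cc3N)c(C)nn12`. Relative to compound 1 the change is 3-amino-5-methylpyridin-2-yl in place of 5-chloropyridin-2-yl on an aromatic carbon. The measured steps that bear on it are those in which the pyridin-2-yl group of compound 1 exchanged chloro for methyl and amino substituents, and all three stayed within the scatter. On that basis compound 4 is expected to show no step beyond the scatter in this assay, that is a 1.1-fold higher number from compound 1 to compound 4 (0.03 log units; within the scatter). The estimate for compound 4 in this assay is 95 nM, with an expected range from 45 nM to 200 nM.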

Compound 4, inhibition constant: 40 nM
Beside the measured number, compound 4's estimate is 2.4-fold (0.38 log units) above it; the measured number lies below the stated range.
By their numbers in this assay, from the lowest: compound 4; then compounds 2, 1 and 3 (each within the scatter of the next).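

In this assay, within the data shown here, 3-amino-5-methylpyridin-2-yl is the first group at this position to move the number beyond the scatter, with a 2.2-fold lower number from compound 1 to compound 4 (0.34 log units; beyond the scatter), a 2.1-fold lower number from compound 2 to compound 4 (0.33 log units; beyond the scatter) and a 2.8-fold lower number from compound 3 to compound 4 (0.44 log units; beyond the scatter), all three modest steps. Among these compounds, the step from compound 2 matters most, since 5-amino-3-methylpyridin-2-yl and 3-amino-5-methylpyridin-2-yl carry the same amino and methyl substituents in a different arrangement, so the result depends on that arrangement and not merely on their presence, and the earlier compounds, all within the scatter of one another, could not show this. No evidence is available on what lies behind this difference.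

The compounds shown leave open whether the amino group would give a similar step with a chloro group in place of the methyl, as in 3-amino-5-chloropyridin-2-yl, or with no second substituent, as in 3-aminopyridin-2-yl. They also leave open whether a hydroxyl or dimethylamino group could take the place of that amino group and keep the number of compound 4, 40 nM.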